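Solubility of a trifluoromethylphenyl amide in the pyrazole series

The compounds below may be only part of what the source reports. "The series", "measured", "known", "first", "only" and "open" are said of these compounds alone.

Compound 1 `CN1CCC(C(=O)N2Cc3c(NC(=O)c4ccsc4)n[nH]c3C2(C)C)CC1` carries a thiophen-3-yl amide on the shared core. In a physicochemical assay for solubility, at pH 7 (on this read-out lower numbers stand for lower solubility and higher numbers for higher solubility), compound 1 gives > 225000 nM, which is a limit of the assay rather than a number. Compound 2 `CN1CCN(C(=O)N2Cc3c(NC(=O)c4ccc(F)cc4)n[nH]c3C2(C)C)CC1`, with a 4-fluorophenyl amide and a different acyl group on the other nitrogen of the core, also sits at a limit in this assay, giving > 225000 nM. Both values shown thus stand at the same limit (the limit of > 225000 nM in this assay, at which 2 of the 2 values shown sit), so compound 1 cannot be placed against compound 2 beyond saying that neither falls below it.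

Compound 3 `CN1CCC(C(=O)N2Cc3c(NC(=O)c4ccc(C(F)(F)F)cc4)n[nH]c3C2(C)C)CC1` differs from compound 1 by 4-(trifluoromethyl)phenyl in place of thiophen-3-yl on a carbonyl carbon. For the measured compounds named here, no step between two measured compounds covers this change, so the size of the expected step rests on the limits alone. Since compound 1 itself is known only as a limit (the limit of > 225000 nM in this assay, at which 2 of the 2 values shown sit), the step from compound 1 to compound 3 is estimated as a modest decrease, an at least 1.8-fold lower number from compound 1 to compound 3 (0.27 log units; that floor lies within the scatter), possibly still within the scatter. Compound 3 is therefore expected to give 120000 nM in this assay, within a range of 30000 nM to 300000 nM.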

Compound 3, solubility: 191000 nM
For compound 3 the middle estimate is 1.6-fold (0.20 log units) below the measured one; the range from low to high includes it.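

Of the three compounds shown, only compound 3 has a number rather than a limit in this assay: compound 3 gives 191000 nM. With 4-(trifluoromethyl)phenyl in place of thiophen-3-yl on a carbonyl carbon, the change reads as an at least 1.1-fold lower number from compound 1 to compound 3 (0.07 log units; that floor lies within the scatter), so no drop beyond the scatter can be claimed, though a larger one is not excluded. This step can be read only as a floor because compound 1 stands at a limit of the assay: the limit of > 225000 nM in this assay, at which 2 of the 3 values shown sit.

For the compounds shown here, the true distance between compound 1 and compound 3 stays open, as does whether a number of this kind goes with 4-(trifluoromethyl)phenyl alone or would also appear with the other acyl group on the core, the one carried by compound 2. Also open, on these data alone, is what a plain phenyl or a pyridin-3-yl on that carbonyl carbon, with the rest of compound 1 unchanged, would give in this assay.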